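Halogen swap on the fused ring: notes on compound 3

The source may report more compounds than this note shows. Statements on the series, on what has been measured and on what is new or still open speak of the compounds shown alone.

Among the compounds with values here, the series so far comprises compound 1 `N#Cc1ccc2ncc(S(=O)(=O)c3ccc(F)cc3)c(-c3ccc(Cl)cc3)c2c1` and compound 2 `O=S(=O)(c1ccc(F)cc1)c1cnc2ccc(Cl)cc2c1-c1ccc(Cl)cc1`. In an ADME assay on microsomes from liver (Homo sapiens) for metabolic stability, tested at 2.5 uM (a lower number here means slower removal, a higher number faster removal of the compound), compound 1 gives 0.01 mL/min, and compound 2 gives 0.01 mL/min. The only step available, no change at the digits printed from compound 1 to compound 2 (within the scatter), leaves compound 2 level with compound 1 at the digits shown, so compound 2 sits at the same low level of the set.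

The next compound is compound 3 `O=S(=O)(c1ccc(F)cc1)c1cnc2ccc(F)cc2c1-c1ccc(Cl)cc1`, which differs from compound 2 as follows: fluoro in place of chloro on an aromatic carbon. Within the data shown here, no measured step involves a fluorine at this position. Among the measured compounds shown here, the one step at this site, no change at the digits printed from compound 1 to compound 2 (within the scatter), was flat, so the substituent there has not yet moved this assay. On that basis the step to compound 3 is expected to be no change at the digits printed from compound 2 to compound 3 (within the scatter), nothing beyond the scatter. Compound 3 is therefore estimated at 0.01 mL/min in this assay, expected between 0.005 mL/min and 0.02 mL/min.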

Compound 3, intrinsic clearance in a liver preparation (reported as CLH), per the amount of preparation that the assay uses: 0.12 mL/min
Beside the measured number, compound 3's estimate is 12-fold (1.08 log units) below it; the whole stated range lies below it.
By their numbers in this assay, from the lowest: compounds 1 and 2 (each within the scatter of the next); then compound 3.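

In this assay the substituent at this position does matter: fluoro stands apart from both other groups (a 12-fold higher number from compound 2 to compound 3 (1.08 log units; beyond the scatter) for fluoro in place of chloro; a 12-fold higher number from compound 1 to compound 3 (1.08 log units; beyond the scatter) for fluoro in place of cyano). The flat step between the cyano and chloro compounds (no change at the digits printed from compound 1 to compound 2 (within the scatter)) therefore does not hold for every substituent here, and exchanging one halogen on an aromatic carbon, with no ring, donor or acceptor entering or leaving, is enough to separate compound 3 from the other two. Nothing at hand explains why this exchange gives faster removal.

On these data alone, whether the rise is peculiar to fluoro or would also appear with hydrogen, a methoxy group or an amine at this site stays open. Also open, as far as these compounds go, is whether the same step would hold with a group other than the chloro on the separate aromatic ring.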